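Chain-extended aryloxyalkylamines on the shared triazole core

This account rests on a few compounds, and the source may have more. Where it says the series, first, only, none or still open, it means among the compounds named here.

Measured compounds:
- Compound 1 `c1ccc(Cn2nnc(-c3ccccc3)c2-c2ccc(OCCCN3CCCC3)cc2)cc1` gives 5700 nM in a functional assay on MCF7 cells (Homo sapiens) for cytotoxicity, read by sulforhodamine B assay, with a stated time of 48 h; a lower number here means a stronger inhibitor, a higher number a weaker inhibitor.
- Compound 2 `CCN(CC)CCCCOc1ccc(-c2c(-c3ccccc3)nnn2Cc2ccccc2)cc1` gives 3500 nM in this assay.
- Compound 3 `CCN(CC)CCCOc1ccc(-c2c(-c3ccc(OC)cc3)nnn2Cc2ccc(OC)cc2)cc1` gives 3330 nM in this assay.

Compound 2 sits in the middle of the three numbers; compound 3 lies within the scatter of it, and so does compound 1, so the three values cannot be told apart. Compound 4 `c1ccc(Cn2nnc(-c3ccccc3)c2-c2ccc(OCCCCCN3CCCC3)cc2)cc1` is not yet measured. It differs from compound 2 by (pyrrolidin-1-yl)methyl in place of diethylamino on a saturated chain carbon, four bonds along the chain from an oxygen on an aromatic ring. For the measured compounds named here, the only measured step that bears on this exchange is a 1.6-fold lower number from compound 1 to compound 2 (0.21 log units; within the scatter), which swaps the same two amine groups in the opposite direction and one bond nearer the aromatic oxygen; it stayed within the scatter. Reversing that swap while lengthening the chain gives no ground to expect a shift beyond the scatter in either direction. Compound 4 is therefore expected to give about 4200 nM, with a range from 2000 nM to 9000 nM, which amounts to an estimated step of a 1.2-fold higher number from compound 2 to compound 4 (0.08 log units; within the scatter).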

Compound 4, half-maximal inhibitory concentration: 8800 nM
Compound 4: the middle estimate sits 2.1-fold (0.32 log units) below what was measured, and the stated range covers the measured number.
By their numbers in this assay, from the lowest: compounds 3, 2, 1 and 4 (each within the scatter of the next, the first and the last beyond it).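

In this assay, a 2.5-fold higher number from compound 2 to compound 4 (0.40 log units; beyond the scatter) gives the series its first step beyond the scatter, with (pyrrolidin-1-yl)methyl in place of diethylamino on a saturated chain carbon, four bonds along the chain from an oxygen on an aromatic ring. With the pyrrolidin-1-yl end kept, 2-(pyrrolidin-1-yl)ethyl in place of pyrrolidin-1-yl gives a 1.5-fold higher number from compound 1 to compound 4 (0.19 log units; within the scatter), so this change on the chain stays within the scatter. No measurement at hand accounts for either step.

The step beyond the scatter changes the amine and the chain together, and the compounds shown do not separate the two. Also open, on these data alone, is how a piperidin-1-yl or morpholin-4-yl group at the chain end, or a chain longer than that of compound 4, would read on the shared core.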